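A few compounds are considered here, and "the series" means these few. Any claim that something is new, unique, unknown or untested is made for them only; others in the source may bear on it.

The compounds measured so far, with their values in a functional assay on CCRF-CEM cells (Homo sapiens), read by MTT assay, with a stated time of 72 h; on this read-out higher numbers stand for weaker inhibition and lower numbers for stronger inhibition:

Compound 1 `Cc1nc(N)c2c(-c3cccs3)cn([C@@H]3O[C@H](CO)[C@@H](O)[C@H]3O)c2n1` gives > 20000 nM, which is a limit of the assay.
Compound 2 `COc1nc(N)nc2c1c(-c1cccs1)cn2[C@@H]1O[C@H](CO)[C@@H](O)[C@H]1O` gives > 20000 nM, which is a limit of the assay.
Compound 3 `C#Cc1cn([C@@H]2O[C@H](CO)[C@@H](O)[C@H]2O)c2nc(C)nc(N)c12` gives > 20000 nM, which is a limit of the assay.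

Compound 1 and compound 3 share a core and differ in one place: ethynyl in place of thiophen-2-yl on an aromatic carbon. Both values sit at the limit, so the step that the two limits leave unreadable from compound 1 to compound 3 cannot be read; the evidence is simply (the limit of > 20000 nM in this assay, at which 3 of the 3 values shown sit). Compound 2 carries a different core from compound 1, and the difference between the two cores is not broken down here.

The unmeasured compound 4 `C#Cc1cn([C@@H]2O[C@H](CO)[C@@H](O)[C@H]2O)c2nc(N)nc(OC)c12` stands to compound 2 as compound 3 stands to compound 1: ethynyl in place of thiophen-2-yl on an aromatic carbon. The place of the change is the same in both pairs, so this is the same change made on the second core.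

Going by the values given here, since compound 2 reaches only a limit in this assay, > 20000 nM, and since the same change from compound 1 to compound 3 left both compounds at that limit, (the limit of > 20000 nM in this assay, at which 3 of the 3 values shown sit), there is no measured step on which to base a size. Compound 4 is expected to remain at the limit as well, and the expected step that the limit leaves unreadable from compound 2 to compound 4 reflects only that. The estimate for compound 4 in this assay is 40000 nM, with a limit rather than a number expected most often.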

Compound 4, half-maximal inhibitory concentration: > 100000 nM
Compound 4 gave a limit, no number; the forecaster's own chance of this, stated with the estimate: 85%; middle value at least 2.5-fold (0.39 log units) from the limit.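

In this assay compound 4 gives > 100000 nM, which is a limit of the assay. Compound 2 gives > 20000 nM, also a limit, and the step between compound 2 and compound 4, ethynyl in place of thiophen-2-yl, cannot be read. The compounds shown leave open how strongly any of them inhibits these cells, and whether either group affects inhibition on either core.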